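Hydrazone variation on a shared dihydropyridine-type core

A few compounds are considered here, and "the series" means these few. Any claim that something is new, unique, unknown or untested is made for them only; others in the source may bear on it.

Measured so far:
Compound 1, `CCOC(=O)C1=C(N/N=C(/Br)c2ccccc2)Nc2[nH]nc(C)c2C1c1ccc(N(C)C)cc1`: 75700 nM
Compound 2, `CCOC(=O)C1=C(NN=C(C(C)=O)C(C)=O)Nc2[nH]nc(C)c2C1c1ccc(N(C)C)cc1`: 17000 nM
Compound 3, `CCOC(=O)C1=C(N/N=C(/C(C)=O)C(=O)OCC)Nc2[nH]nc(C)c2C1c1ccc(N(C)C)cc1`: > 100000 nM (a limit)

In a functional assay on HeLa cells (Homo sapiens) for inhibition, read by MTT assay, with a stated time of 48 h (on this read-out lower numbers stand for stronger inhibition and higher numbers for weaker inhibition), compound 1 gives 75700 nM, the higher of the two numbers shown. Compound 2 gives 17000 nM, with a 4.5-fold lower number from compound 1 to compound 2 (0.65 log units; beyond the scatter). For compound 3 the assay reports only a limit, > 100000 nM (the limit of > 100000 nM in this assay, at which 1 of the 3 values shown sits), so compound 1 and compound 3 cannot be ordered with confidence.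

Compound 4, `CCOC(=O)C1=C(N/N=C(/C(=O)Br)c2ccc(Cl)cc2)Nc2[nH]nc(C)c2C1c1ccc(N(C)C)cc1`, differs from compound 1 in one place: a group of 12 heavy atoms (8 carbon, 1 nitrogen, 1 oxygen, 1 chlorine, 1 bromine; one six-membered aromatic ring of carbon only) in place of a group of 9 heavy atoms (7 carbon, 1 nitrogen, 1 bromine; one six-membered aromatic ring of carbon only), on an amine nitrogen. Both measured steps from compound 1 replace the aromatic-ring group with a chain group that carries no ring, and they point in opposite directions: a 4.5-fold lower number from compound 1 to compound 2 (0.65 log units; beyond the scatter) and an at least 1.3-fold higher number from compound 1 to compound 3 (0.12 log units; that floor lies within the scatter). Within the data shown here, compound 4 keeps the aromatic ring and adds a carbonyl and a chlorine, a change for which no measured step is a close guide. The expected result for compound 4 in this assay is therefore no step beyond the scatter, with a 1.1-fold lower number from compound 1 to compound 4 (0.03 log units; within the scatter); compound 4 is expected at about 70000 nM, in a range from 25000 nM to 200000 nM.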

Compound 4, half-maximal inhibitory concentration: 49300 nM
Estimate against measurement, compound 4: 1.4-fold (0.15 log units) above; low and high end bracket the measured number.
By their numbers in this assay, from the lowest: compound 2; then compounds 4 and 1 (each within the scatter of the next). At a limit, above all of these: compound 3.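

In this assay, the group entering at the amine nitrogen in compound 4 keeps the six-membered aromatic ring and adds a carbonyl and a chlorine, yet the change stays within the scatter, with a 1.5-fold lower number from compound 1 to compound 4 (0.19 log units; within the scatter). Among these compounds, this position therefore takes a larger ring-bearing group with no step that can be told from the scatter, while the ring-free group of compound 2 still gives the lowest number, with a 2.9-fold higher number from compound 2 to compound 4 (0.46 log units; beyond the scatter). Compound 3 stands at a limit: the limit of > 100000 nM in this assay, at which 1 of the 4 values shown sits. The reading an at least 2.0-fold lower number from compound 3 to compound 4 (0.30 log units; that floor lies within the scatter) rests on that limit and does not order the two compounds with confidence.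

The carbonyl and the chlorine enter together in compound 4, and the compounds shown do not separate them. Also open, going by these compounds, is how a group carrying an amine or a carboxylic acid at this position, or a methoxy in place of the chlorine, would read in this assay.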